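The compounds below may be only part of what the source reports. "The series", "measured", "known", "first", "only" and "open" are said of these compounds alone.

Working notes on the series. Compound 1 `NS(=O)(=O)Oc1ccc2c(c1)CN(C(=O)c1cccc(N3CCCCC3)c1)CC2` gives 1% in an assay on HEK293 cells for inhibition of Steryl-sulfatase (Homo sapiens), tested at 0.1 uM (a higher number here means a stronger effect of the compound at the concentration tested, a lower number a weaker effect), and among the three measured numbers it lies at the low end, with both others within the usual scatter of it. The nearest is compound 3 `NS(=O)(=O)Oc1ccc2c(c1)CN(C(=O)c1cccc(N3CCC(Cc4ccccc4)CC3)c1)CC2`, which gives 1.4%; the step of a number 0.4 percentage points higher from compound 1 to compound 3 (within the scatter) stays within the scatter. The furthest is compound 2 `NS(=O)(=O)Oc1ccc2c(c1)CN(C(=O)c1ccc(N(CCCO)Cc3ccccc3)cc1)CC2`, which gives 5.7%, a number that is also within the scatter of compound 1.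

Compound 4 `CCN(Cc1ccccn1)c1cccc(C(=O)N2CCc3ccc(OS(N)(=O)=O)cc3C2)c1` is the next candidate. Relative to compound 1 it carries ethyl((pyridin-2-yl)methyl)amino in place of piperidin-1-yl on an aromatic carbon, on an aromatic carbon of a six-membered aromatic ring of carbon only, meta to a large group.

For the measured compounds named here, only one measured step touches the same amine position, the one from compound 1 to compound 3, and it changed nothing beyond the scatter. Going by the values given here, no measured step exchanges a saturated ring amine for an open-chain ethyl((pyridin-2-yl)methyl)amino, so the change is not directly covered. Given that every number so far sits within the scatter of compound 1, the expectation for compound 4 in this assay is no step beyond the scatter, expressed as a number 1.5 percentage points higher from compound 1 to compound 4 (within the scatter). Compound 4 is therefore estimated at 2.5%, within a range from 0% to 9%.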

Compound 4, a percentage reported as inhibition, at one concentration (the size of the read-out at that concentration, not a potency): 6.5%
Compound 4: the middle estimate sits 4 percentage points below what was measured; measured number inside the range.
By their numbers in this assay, from the lowest: compounds 1, 3, 2 and 4 (each within the scatter of the next).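

The exchange of piperidin-1-yl for ethyl((pyridin-2-yl)methyl)amino on an aromatic carbon, meta to a large group, gives in this assay a number 5.5 percentage points higher from compound 1 to compound 4 (within the scatter). Unlike the earlier step at this amine, which kept the saturated ring and added benzyl to it, this change removes that ring altogether and brings in an open-chain amine carrying a six-membered aromatic ring with one hetero atom, and even this larger alteration produces no step beyond the scatter. No information is available to explain this outcome.

The compounds shown leave open whether any substituent at this aromatic carbon can lift the read-out beyond the scatter of compound 1, since neither of the two steps from compound 1 at this position does so. A morpholine ring, a primary amine or a carboxylic acid in place of piperidin-1-yl would test whether the flat result extends to groups of a different kind from the tertiary amines seen so far.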